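Methyl at the Chain Carbon, on a Shorter Linker

The source may hold more compounds than are shown below. What is called first, only, known or untested is meant among the compounds shown, and "the series" means these compounds.

Compound 1 `CC1=C(CCC(=O)OCCCCOc2no[n+]([O-])c2S(=O)(=O)c2ccccc2)C(=O)c2c(O)cccc2C1=O` and compound 2 `CC1=C(C(C)CC(=O)OCCCCOc2no[n+]([O-])c2S(=O)(=O)c2ccccc2)C(=O)c2c(O)cccc2C1=O` share one core and differ by methyl in place of hydrogen on a saturated chain carbon bound to a double-bonded ring carbon and a saturated chain carbon. In a functional assay on MDA-MB-231 cells (Homo sapiens) for inhibition, read by MTT assay, with a stated time of 72 h (a higher number here means a weaker inhibitor, a lower number a stronger inhibitor), compound 1 gives 1240 nM, while compound 2 gives 1980 nM; the change made a 1.6-fold higher number from compound 1 to compound 2 (0.20 log units; within the scatter). Compound 3 `CC1=C(CCC(=O)OCCCOc2no[n+]([O-])c2S(=O)(=O)c2ccccc2)C(=O)c2c(O)cccc2C1=O` stands apart from these two: the difference between its core and that of compound 1 is not broken down here. In this assay compound 3 gives 4310 nM, the highest of the three numbers. Compound 4 `CC1=C(C(C)CC(=O)OCCCOc2no[n+]([O-])c2S(=O)(=O)c2ccccc2)C(=O)c2c(O)cccc2C1=O` has not yet been measured; it differs from compound 3 by methyl in place of hydrogen on a saturated chain carbon bound to a double-bonded ring carbon and a saturated chain carbon, the same change that separates compound 1 and compound 2. On that basis the step is expected to be a 1.5-fold higher number from compound 3 to compound 4 (0.18 log units; within the scatter), resting on a 1.6-fold higher number from compound 1 to compound 2 (0.20 log units; within the scatter). Compound 4 is therefore estimated at 6500 nM, with a range from 3500 nM to 12000 nM.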

Compound 4, half-maximal inhibitory concentration: 2420 nM
Beside the measured number, compound 4's estimate is 2.7-fold (0.43 log units) above it, and the stated range ends above it.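

In this assay, methyl in place of hydrogen on the saturated chain carbon gave a 1.8-fold lower number from compound 3 to compound 4 (0.25 log units; within the scatter), and each step taken alone lies within the scatter. Set side by side, however, the two steps differ: the same change on two cores in this assay, a 1.6-fold higher number (0.20 log units; within the scatter) from compound 1 to compound 2 and a 1.8-fold lower number (0.25 log units; within the scatter) from compound 3 to compound 4, 2.8-fold (0.45 log units) apart, beyond the scatter of two such steps

Going by these compounds alone, this shows that, across these two cores, the change did not carry over as a fixed step, but with only two cores it gives no rule for any other core and does not show why the steps differ. The compounds shown leave open how the same change would behave on a core with a longer chain in the linker. They also leave open whether an ethyl group at that saturated chain carbon would follow the methyl.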